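A few compounds are considered here, and "the series" means these few. Any claim that something is new, unique, unknown or untested is made for them only; others in the source may bear on it.

Compound 1 `CCOc1cc(NC(=O)C2(NC(=O)c3ccc4c(C5CCCC5)c(-c5ncc(Cl)cn5)n(C)c4c3)CCC2)ccc1/C=C/C(=O)OC(=O)C[C@H](O)C(=O)O` is measured in an ADME assay (liver) for pharmacokinetics, with Liver microsome (Homo sapiens) as the target, using microsomes (a higher number here means that the compound lasts longer, a lower number that the compound disappears faster), at 5.57 h, the highest of the three numbers available here. Compound 2 `CCOc1cc(NC(=O)C2(NC(=O)c3ccc4c(C5CCCC5)c(-c5ncc(Cl)cn5)n(C)c4c3)CCC2)ccc1/C=C/C(=O)OCCOCCOC` gives 0.85 h in this assay, and compound 3 `CCOc1cc(NC(=O)C2(NC(=O)c3ccc4c(C5CCCC5)c(-c5ncc(Cl)cn5)n(C)c4c3)CCC2)ccc1/C=C/C(=O)OCC(=O)OC` gives 2.1 h. Compound 4 `CCOc1cc(NC(=O)C2(NC(=O)c3ccc4c(C5CCCC5)c(-c5ncc(Cl)cn5)n(C)c4c3)CCC2)ccc1/C=C/C(=O)OCC(=O)OCc1ccc(Cl)cc1` is not yet measured; it differs from compound 1 as follows: (((4-chlorobenzyl)oxy)carbonyl)methyl in place of (2-carboxy-2-hydroxyethyl)carbonyl on an oxygen next to a carbonyl group. Among the measured compounds shown here, two measured steps bear on this change, each replacing the same (2-carboxy-2-hydroxyethyl)carbonyl group on an oxygen next to a carbonyl group: a 6.6-fold lower number from compound 1 to compound 2 (0.82 log units; beyond the scatter) and a 2.7-fold lower number from compound 1 to compound 3 (0.42 log units; beyond the scatter). Both run downward and beyond the scatter. The group entering in compound 4 resembles the (methoxycarbonyl)methyl of compound 3 more closely than the 2-(2-methoxyethoxy)ethyl of compound 2, so a downward step of roughly the size seen to compound 3, or somewhat larger, is expected. The expected step is a 3.7-fold lower number from compound 1 to compound 4 (0.57 log units; beyond the scatter). Compound 4 is therefore estimated at 1.5 h in this assay, with a range of 0.6 h to 4 h.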

Compound 4, half-life: 5.62 h
Compound 4: middle estimate off by 3.7-fold (0.57 log units), on the low side; the measured number lies above the stated range.
By their numbers in this assay, from the lowest: compound 2; then compound 3; then compounds 1 and 4 (each within the scatter of the next).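

In this assay, replacing the (2-carboxy-2-hydroxyethyl)carbonyl group on this oxygen need not lower the number: (((4-chlorobenzyl)oxy)carbonyl)methyl gives (a 1.0-fold higher number from compound 1 to compound 4 (0.00 log units; within the scatter)). The downward steps seen with the two earlier replacements therefore do not hold for every group at this place, and the 2 hydrogen-bond donors of the leaving group are not required for a number at this level. Among the replacements, 4-chlorophenyl in place of hydrogen on the saturated chain carbon gives (a 2.7-fold higher number from compound 3 to compound 4 (0.43 log units; beyond the scatter)), and ((4-chlorobenzyl)oxy)carbonyl in place of (2-methoxyethoxy)methyl gives (a 6.6-fold higher number from compound 2 to compound 4 (0.82 log units; beyond the scatter)).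

No measured finding here accounts for these differences. Still open, from the compounds shown here alone, is whether the chlorine or the aromatic ring carries the rise, a question that an unsubstituted benzyl group at the same place would address.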